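Extending the Side Chain from Compound 2 to Compound 4

A few compounds are considered here, and "the series" means these few. Any claim that something is new, unique, unknown or untested is made for them only; others in the source may bear on it.

Of the compounds shown here, three sharing one core have been measured in a functional assay on the whole organism (Tail, strain ICR) with Mus musculus as the target, in the tail flick test, with a stated time of 150 min, at a dose of 25 umol/kg by the oral route; on this read-out higher numbers stand for a stronger effect at the one dose given and lower numbers for a weaker effect. Compound 1 `O=C(O)[C@@H]1CCCN1C(=O)CN(c1nc(Cl)nc2[nH]cnc12)C1CC1` gives 7.29% in this assay. Compound 2 `C[C@H](NC(=O)CN(c1nc(Cl)nc2[nH]cnc12)C1CC1)C(=O)O` gives 14.7%, and compound 3 `C[C@H](NC(=O)CN(c1nc(Cl)nc2[nH]cnc12)C1CC1)C(=O)OCc1ccccc1` gives 23%. Compound 2 stands second highest of the three numbers; its nearest neighbour is compound 1 and its furthest is compound 3, and both gaps lie within the scatter, so no order among them can be claimed. The step of a number 7.4 percentage points higher from compound 1 to compound 2 (within the scatter) came with (1-carboxyethyl)amino in place of 2-carboxypyrrolidin-1-yl on a carbonyl carbon, and the step of a number 8.3 percentage points higher from compound 2 to compound 3 (within the scatter) came with benzyl in place of hydrogen on an oxygen next to a carbonyl group. Neither step is beyond the scatter.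

Compound 4 `NCCCC[C@H](NC(=O)CN(c1nc(Cl)nc2[nH]cnc12)C1CC1)C(=O)O` differs from compound 2 by 3-aminopropyl in place of hydrogen on a saturated chain carbon, two bonds along the chain from an amide-type nitrogen and a carbonyl carbon. Among the compounds with values here, none of the measured steps alters this very position, yet the two that change the same end of the molecule each stayed within the scatter, so a step beyond the scatter in this assay is not expected in either direction. Compound 4 is therefore expected to give about 15% in this assay, within a range from 3% to 30%. The estimated step is a number 0.3 percentage points higher from compound 2 to compound 4 (within the scatter).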

Compound 4, a percentage reported as activity, at one dose (the size of the read-out at that dose, not a potency): 11.6%
Compound 4: middle estimate off by 3.4 percentage points, on the high side; measured number inside the range.
By their numbers in this assay, from the lowest: compounds 1, 4, 2 and 3 (each within the scatter of the next, the first and the last beyond it).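

This is the first change shown at the saturated chain carbon itself, two bonds along the chain from an amide-type nitrogen and a carbonyl carbon, and in this assay it gives a number 3.1 percentage points lower from compound 2 to compound 4 (within the scatter) as its step. The same difference can be read as methyl to 4-aminobutyl, so this position takes an open chain ending in an amine, with 4 further heavy atoms and no ring, without a step beyond the scatter, as the two earlier changes at the acid end of the molecule also did. No measurement is at hand that would explain the size of this step.

The compounds shown leave open whether a shorter or longer chain at this carbon, such as ethyl or 6-aminohexyl, or a chain ending in a carboxylic acid or a hydroxyl group instead of the amine, would stay within the scatter as well. They also leave open how 3-aminopropyl at this carbon reads when the carboxylic acid carries a benzyl group, the change that separates compound 2 from compound 3.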